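The source may report more compounds than this note shows. Statements on the series, on what has been measured and on what is new or still open speak of the compounds shown alone.

Values measured in a functional assay on the whole organism for antagonist activity, with Mus musculus as the target; a lower number here means that less compound is needed, a higher number that more compound is needed for the effect:

- compound 1 `CCCCCC(=O)NCC(=O)N(C)c1ccc(Cl)cc1C(=O)c1ccccc1Cl`: 1.9 mg/kg
- compound 2 `CC(C)NCC(=O)NCC(=O)N(C)c1ccc(Cl)cc1C(=O)c1ccccc1Cl`: 1 mg/kg
- compound 3 `CC(=O)NCC(=O)N(C)c1ccc(Cl)cc1C(=O)c1ccccc1Cl`: 2.3 mg/kg

Compound 3 gives 2.3 mg/kg and does not separate from compound 1, as a 1.2-fold higher number from compound 1 to compound 3 (0.08 log units; within the scatter) shows. It does separate from compound 2, though only modestly: a 2.3-fold higher number from compound 2 to compound 3 (0.36 log units; beyond the scatter).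

The compound still to be measured is compound 4 `CC(NC(=O)CN)C(=O)N(C)c1ccc(Cl)cc1C(=O)c1ccccc1Cl`. The structural change is 1-(((aminomethyl)carbonyl)amino)ethyl in place of acetamidomethyl on a carbonyl carbon. In words, 1-(((aminomethyl)carbonyl)amino)ethyl takes the place of acetamidomethyl on a carbonyl carbon.

For the measured compounds named here, all the measured steps swap a group on a saturated chain carbon bound to a carbonyl carbon, and compound 4 also has an amino group at such a carbon. The closest guide is therefore compound 2, which carries isopropylamino there and lies on the lower side of compound 3 by a 2.3-fold higher number from compound 2 to compound 3 (0.36 log units; beyond the scatter). Compound 1 shows that a group without nitrogen gave only a 1.9-fold lower number from compound 1 to compound 2 (0.28 log units; within the scatter) against compound 2. Going by the values given here, no measured compound tests the added ethyl part of the new group, so the uncertainty stays wide.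

A small move toward a lower number is expected, about the size seen with compound 2: a 1.8-fold lower number from compound 3 to compound 4 (0.25 log units; within the scatter). For compound 4 the estimate is 1.3 mg/kg, with an expected range from 0.5 mg/kg to 3.5 mg/kg.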

Compound 4, dose for half-maximal effect: 0.47 mg/kg
For compound 4 the middle estimate is 2.8-fold (0.44 log units) above the measured one; measured number below the stated range.
By their numbers in this assay, from the lowest: compound 4; then compounds 2, 1 and 3 (each within the scatter of the next, the first and the last beyond it).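

In this assay, the swap on this carbonyl carbon, whose other neighbour is an amide-type nitrogen, moves the number further than any earlier step: 1-(((aminomethyl)carbonyl)amino)ethyl in place of acetamidomethyl gives a 4.9-fold lower number from compound 3 to compound 4 (0.69 log units; beyond the scatter). For the compounds shown here, the same group also stands apart from the two other side chains, with a 2.1-fold lower number from compound 2 to compound 4 (0.33 log units; beyond the scatter) and a 4.0-fold lower number from compound 1 to compound 4 (0.61 log units; beyond the scatter), so the lowest number of the four belongs to compound 4, the only compound whose steps to all the others lie beyond the scatter. Earlier swaps at the far end of the chain moved the number less, so the largest shift here comes from a change that reaches the carbon directly on the carbonyl, although no measurement shown explains why the number falls.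

The new group differs from acetamidomethyl in two parts at once, the ethyl in place of methyl and the amine on the aminomethyl end, and the compounds shown do not separate what each part contributes. A 1-acetamidoethyl group, which has the ethyl without that amine, would help pull the two apart, and a longer chain carrying the amine would show how far that end can be extended.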